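The source may hold more compounds than are shown below. What is called first, only, known or untested is meant among the compounds shown, and "the series" means these compounds.

Measured so far:
- compound 1 `CN1CCC(c2c[nH]c3cnc(NC(=O)c4ccc(F)cc4)cc23)CC1`: 13 nM
- compound 2 `CN1CCC(c2c[nH]c3ccc(NC(=O)C4CC4)nc23)CC1`: 9.8 nM

In an assay for binding affinity to 5-hydroxytryptamine receptor 1F (Homo sapiens), read by radioligand binding (on this read-out lower numbers stand for stronger inhibition and higher numbers for weaker inhibition), compound 2 gives 9.8 nM and compound 1 gives 13 nM; the two values lie within the scatter of each other, so neither is set apart. Compound 3 `Cc1cccc(C(=O)Nc2ccc3[nH]cc(C4CCN(C)CC4)c3n2)c1` is not yet measured in this assay. Against compound 2 it carries 3-methylphenyl in place of cyclopropyl on a carbonyl carbon. For the measured compounds named here, no measured pair covers this change. Compound 1 already carries an aryl amide on another core and gives 13 nM, so the expected step from compound 2 to compound 3 is a 1.2-fold higher number from compound 2 to compound 3 (0.09 log units; within the scatter), within the scatter. Compound 3 is estimated at 12 nM, range 4 nM to 36 nM.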

Compound 3, inhibition constant: 5.8 nM
For compound 3 the middle estimate is 2.1-fold (0.32 log units) above the measured one; the range from low to high includes it.
By their numbers in this assay, from the lowest: compounds 3, 2 and 1 (each within the scatter of the next, the first and the last beyond it).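

In this assay, 3-methylphenyl in place of cyclopropyl on a carbonyl carbon gives a 1.7-fold lower number from compound 2 to compound 3 (0.23 log units; within the scatter), so on the shared core this position holds either ring without a step that clears the scatter. For the compounds shown here, compound 1 carries its aryl amide on another core, so this is the first reading of the change on one core. Nothing at hand gives a reason for the step.

Still open, on these data alone, is whether a longer chain in place of the ring stays in this range. Also open, as far as these compounds go, is what an amine or a carboxylic acid on the phenyl ring would do in place of the methyl.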